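This account rests on a few compounds, and the source may have more. Where it says the series, first, only, none or still open, it means among the compounds named here.

Measured compounds:
Compound 1, `Cc1ccccc1/C(CCN1CCN(c2ccccn2)CC1)=N/O`: in a functional assay on HEK293 cells with D(4) dopamine receptor (Homo sapiens) as the target, read by FLIPR (on this read-out higher numbers stand for larger maximal responses and lower numbers for smaller maximal responses), compound 1 gives 82%.
Compound 2, `CO/N=C(\CCN1CCN(c2ccccn2)CC1)c1ccccc1Cl`: compound 2 gives 79%.
Compound 3, `CO/N=C(/CCN1CCN(c2ccccn2)CC1)c1ccccc1Cl`: compound 3 gives 73%.

Compound 2 stands second highest of these three numbers, but its nearest neighbour, compound 1, and its furthest, compound 3, both lie within the usual scatter of it, so the three compounds cannot be told apart on this read-out. For the measured compounds named here, the only step among them with a single change is a number 6 percentage points lower from compound 2 to compound 3 (within the scatter), and that small step fits with the fact that compounds 2 and 3 differ only in the configuration as drawn.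

Compound 4, `CO/N=C(\CCN1CCN(c2ccccn2)CC1)c1ccccc1C`, has not yet been measured. It differs from compound 2 in one place: methyl in place of chloro on an aromatic carbon. Going by the values given here, no measured step involves this swap, so the measured steps give no direct guide. Compound 1 carries the 2-methylphenyl group too, with a different oxime substituent, and its value sits within the scatter of compound 2, which hints that the methyl group is tolerated. Compound 4 is therefore expected to give 80%, with a range from 65% to 92%. The expected step of a number 1 percentage points higher from compound 2 to compound 4 (within the scatter) stays within the scatter, in no firm direction.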

Compound 4, largest response reached (reported as efficacy), in percent of the reference or control that the assay uses: 80%
Beside the measured number, compound 4's estimate shows no gap at the digits printed, and the stated range covers the measured number.
By their numbers in this assay, from the lowest: compounds 3, 2, 4 and 1 (each within the scatter of the next).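

For the compounds shown here, changing 2-chlorophenyl to 2-methylphenyl in this assay gives a number 1 percentage points higher from compound 2 to compound 4 (within the scatter) and so, on this aromatic carbon ortho to a large group, this read-out does not separate chloro from methyl, a direct comparison that the earlier compounds could only hint at. Going by these compounds alone, compound 4 also gives the first direct comparison at the oxygen of the oxime with the 2-methylphenyl group in place: methyl in place of hydrogen gives a number 2 percentage points lower from compound 1 to compound 4 (within the scatter) and, within this pair, the maximal response does not tell the two groups apart. The one available explanatory fact concerns a different pair of compounds and a difference in drawn configuration, so it offers no reason for either of these two results.

What the compounds shown leave open is whether the maximal response would hold with an amine, a methoxy group or a trifluoromethyl group on the same aromatic carbon. On these data alone, it is also open whether a longer chain, such as propyl or butyl, on the oxime oxygen would fit the same picture.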